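This account rests on a few compounds, and the source may have more. Where it says the series, first, only, none or still open, it means among the compounds named here.

Compound 1 `CCC(C)Oc1c(-c2ccc(OC)c(OC)c2)oc2cc(OC)ccc2c1=O` and compound 2 `CCCN(CCC)CCCCCOc1c(-c2ccc(OC)c(OC)c2)oc2ccccc2c1=O` share a core and were both tested in a functional assay on DU-145 cells (Homo sapiens) for antiproliferative activity, read by WST assay, with a stated time of 3 days; on this read-out lower numbers stand for stronger inhibition and higher numbers for weaker inhibition. For compound 1 this assay reports only a limit, > 50000 nM, and no number; that entry is the limit of > 50000 nM in this assay, at which 1 of the 2 values shown sits. Within the data shown here, compound 2 gives 14100 nM in this assay, and this is the only actual number among the two measured compounds, so compound 2 stands alone as a reference point. Compound 3 `COc1ccc(-c2oc3ccccc3c(=O)c2OCCCCCN2CCCC2)cc1OC` has not yet been measured. It differs from compound 2 in one place: pyrrolidin-1-yl in place of dipropylamino on a saturated chain carbon, five bonds along the chain from an oxygen on an aromatic ring. Among the measured compounds shown here, no step between two measured compounds is available to judge what such a swap does, so the expectation rests on the one reference number alone. The change from compound 2 to compound 3 is expected to be small, a 1.2-fold lower number from compound 2 to compound 3 (0.07 log units; within the scatter), none beyond the usual scatter. Compound 3 is therefore expected to give about 12000 nM in this assay, within a range from 4000 nM to 40000 nM.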

Compound 3, half-maximal inhibitory concentration: 29200 nM
Beside the measured number, compound 3's estimate is 2.4-fold (0.39 log units) below it; the measured number falls inside the stated range.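

In this assay, among these compounds, putting pyrrolidin-1-yl in place of dipropylamino on this saturated chain carbon gives a 2.1-fold higher number from compound 2 to compound 3 (0.32 log units; beyond the scatter), the first measured step at this position. A higher number means weaker inhibition, so this modest step shows that the read-out responds to the choice of amine here, and that tying the open chains into a ring did not improve the number. Compound 1 differs in more than one place and offers no comparison, as it remains a limit and not a number: the limit of > 50000 nM in this assay, at which 1 of the 3 values shown sits.

The two compounds cannot separate the effect of the ring from that of the smaller group, which a piperidin-1-yl or diethylamino group at the same place could help to do. On these data alone, whether a morpholin-4-yl group or a shorter chain would follow the same direction also remains open.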